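Removing the 4-methylphenyl from a thiazolidinedione acrylamide

The compounds below may be only part of what the source reports. "The series", "measured", "known", "first", "only" and "open" are said of these compounds alone.

Measured compounds:
- compound 1 `C=C(Br)C(=O)Nc1ccc(/C=C2\SC(=O)N(Cc3ccc(C)cc3)C2=O)cc1` gives 3700 nM
- compound 2 `Nc1ccc(/C=C2\SC(=O)N(Cc3cccc(Cl)c3)C2=O)cc1` gives 18000 nM
- compound 3 `Cc1ccc(CN2C(=O)S/C(=C\c3cccc(N)c3)C2=O)cc1` gives > 250000 nM

In a functional assay on CCRF-CEM cells (Homo sapiens) for cytotoxicity, read by cell counting, with a stated time of 3 days (a lower number here means a stronger inhibitor, a higher number a weaker inhibitor), compound 1 gives the lower of the two numbers, and compound 2 sits at a higher number beyond the scatter. Compound 3 reaches only a limit of the assay, (the limit of > 250000 nM in this assay, at which 1 of the 3 values shown sits). The unmeasured compound 4 `C=C(Br)C(=O)Nc1ccc(/C=C2\SC(=O)N(C)C2=O)cc1` differs from compound 1 by hydrogen in place of 4-methylphenyl on a saturated chain carbon bound to an amide-type nitrogen in a ring, so the 4-methylbenzyl becomes a methyl while the bromoacrylamide and the shared core remain. Among the compounds with values here, since no step between measured compounds touches this position, the direction rests on expectation alone: losing the aromatic ring is expected to weaken inhibition in this assay. The step from compound 1 to compound 4 is estimated as a 4.1-fold higher number from compound 1 to compound 4 (0.61 log units; beyond the scatter). Compound 4 is therefore expected to give about 15000 nM, within 4000 nM to 60000 nM.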

Compound 4, half-maximal inhibitory concentration: 360 nM
Estimate against measurement, compound 4: 42-fold (1.62 log units) above, outside the stated range (below it).
By their numbers in this assay, from the lowest: compound 4; then compound 1; then compound 2. At a limit, above all of these: compound 3.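

In this assay, going from 4-methylbenzyl to methyl gives a 10-fold lower number from compound 1 to compound 4 (1.01 log units; beyond the scatter), the first step read at this position. The aromatic ring here is therefore not needed for a low number, and in this pair, its loss strengthens inhibition. Nothing measured here explains this gain.

The compounds shown leave open what an ethyl group, a longer chain or a chain ending in an amine would give at this place. A single step cannot tell whether the number falls steadily as the group shrinks or whether some intermediate size does best.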